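A Peroxide Acid and Its Ring Diastereomer

The compounds below may be only part of what the source reports. "The series", "measured", "known", "first", "only" and "open" are said of these compounds alone.

Compound 1 `C=C1CCCC(C)(C)C1CC[C@]1(C)CC[C@@H]([C@@H](C)C(=O)O)OO1`: in a functional assay on A549 cells (Homo sapiens) for cytotoxicity, read by colony formation (on this read-out lower numbers stand for stronger inhibition of growth and higher numbers for weaker inhibition of growth), compound 1 gives only a limit, > 5000 nM.
Compound 2 `C=C1CCCC(C)(C)C1CC[C@]1(C)CC[C@H]([C@@H](C)C(=O)OC)OO1`: in this assay compound 2 gives 640 nM.
Compound 3 `C=C1CCCC(C)(C)C1(O)CC/C(C)=C/CC[C@]1(C)CC[C@@H]([C@@H](C)C(=O)OC)OO1`: in this assay compound 3 gives only a limit, > 5000 nM.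

Going by the values given here, compound 1 therefore stands at the limit of > 5000 nM in this assay, at which 2 of the 3 values shown sit, and no numerical potency is known for it; no pair of measured compounds differs in just one place, so no measured step is available. Compound 4 `C=C1CCCC(C)(C)C1CC[C@@]1(C)CC[C@H]([C@@H](C)C(=O)O)OO1` keeps every atom and bond of compound 1 and differs only in configuration: the two compounds have the same atoms and bonds; at least one stereo element is drawn with a configuration in one of them and without one in the other: 2 of 4 stereo elements differ; a stereocentre at a saturated ring carbon is drawn R in compound 1 and S in compound 4; a stereocentre at a saturated ring carbon is drawn S in compound 1 and R in compound 4. With nothing measured to lean on, the step that the limit leaves unreadable from compound 1 to compound 4 is expected to stay within the scatter. Compound 4 is estimated at 7000 nM, between 2000 nM and 25000 nM, and is expected most likely to be reported as a limit again.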

Compound 4, concentration for 50% growth inhibition: 3050 nM
For compound 4 the middle estimate is 2.3-fold (0.36 log units) above the measured one, within the range that was stated.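

Reversing the configuration at the two saturated ring carbons gives a measurable result for this acid: in this assay compound 4 gives 3050 nM. The change reads as an at least 1.6-fold lower number from compound 1 to compound 4 (0.21 log units; that floor lies within the scatter), so a real effect of configuration is neither shown nor ruled out. The true size of the step stays hidden, since compound 1 has only a limit, not a number: the limit of > 5000 nM in this assay, at which 2 of the 4 values shown sit.

From the compounds shown here alone, the contribution of each ring carbon on its own remains open. So does the result of replacing the carboxylic acid of compound 4 with an amide.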